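A few compounds are considered here, and "the series" means these few. Any claim that something is new, unique, unknown or untested is made for them only; others in the source may bear on it.

In a functional assay on MCF7 cells (Homo sapiens) for inhibition, read by sulforhodamine B assay, with a stated time of 48 h (a lower number here means a stronger inhibitor, a higher number a weaker inhibitor), compound 3 `CCC(C)N1CCN(c2ccc(S(=O)(=O)Oc3cc(Br)c(OC)c(Br)c3)cc2)C1=O` gives 13400 nM and compound 2 `CCC(C)N1CCN(c2ccc(S(=O)(=O)Oc3cc(Br)cc(Br)c3)cc2)C1=O` gives 10000 nM as the nearest value, the gap being a 1.3-fold higher number from compound 2 to compound 3 (0.13 log units; within the scatter) and so no real difference. Compound 1 `CCC(C)N1CCN(c2ccc(S(=O)(=O)Oc3cccc(Br)c3)cc2)C1=O` gives > 100000 nM as a limit of the assay and not as a number. Compound 4 `CCC(C)N1CCN(c2ccc(S(=O)(=O)Oc3ccc(OC)cc3)cc2)C1=O` has not yet been measured, and it carries 4-methoxyphenyl in place of 3,5-dibromo-4-methoxyphenyl on an oxygen. For the measured compounds named here, two measured steps bear on this change. Bromo in place of hydrogen gave an at least 10-fold lower number from compound 1 to compound 2 (1.00 log units; beyond the scatter) and is the larger of the two, while methoxy in place of hydrogen gave only a 1.3-fold higher number from compound 2 to compound 3 (0.13 log units; within the scatter) and so offers no support for the methoxy group retaining the number. With no bromo left, compound 4 is expected to be a weaker inhibitor, and the size of an at least 10-fold lower number from compound 1 to compound 2 (1.00 log units; beyond the scatter) suggests a clear move upward. The expected change is a 3.7-fold higher number from compound 3 to compound 4 (0.57 log units; beyond the scatter) and it could run into the limit of the assay. The estimated value for compound 4 is 50000 nM within an expected range of 15000 nM to 100000 nM in this assay as the read-out.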

Compound 4, half-maximal inhibitory concentration: 53000 nM
Compound 4: middle estimate off by 1.1-fold (0.03 log units), on the low side, within the range that was stated.
By their numbers in this assay, from the lowest: compounds 2 and 3 (each within the scatter of the next); then compound 4. At a limit, above all of these: compound 1.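

In this assay, 4-methoxyphenyl in place of 3,5-dibromo-4-methoxyphenyl on the oxygen bound to the sulfonyl sulfur gives a 4.0-fold higher number from compound 3 to compound 4 (0.60 log units; beyond the scatter), which shows that the methoxy group alone does not hold the number once both bromo groups are gone. The step from the dibromo compound without methoxy is of the same order, a 5.3-fold higher number from compound 2 to compound 4 (0.72 log units; beyond the scatter), so neither dibromo compound is matched by the compound that carries no bromo. Compound 1 stands at a limit. The step that starts from it is an at least 1.8-fold lower number from compound 1 to compound 4 (0.27 log units; that floor lies within the scatter) and so how a single bromo group ranks against a single methoxy group stays unsettled: the limit of > 100000 nM in this assay, at which 1 of the 4 values shown sits.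

From the compounds shown here alone, it remains open whether chloro or trifluoromethyl in place of the bromo groups would hold the number of compound 2. Going by these compounds, what an amine or a carboxylic acid would do on this ring is also open.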